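Amide series on the shared core: notes toward compound 4

A few compounds are considered here, and "the series" means these few. Any claim that something is new, unique, unknown or untested is made for them only; others in the source may bear on it.

Compound 1 `NC(=O)c1c(NC(=O)c2ccc(C(F)(F)F)cc2)sc2c1CCN(Cc1ccc(Cl)cc1Cl)C2` gives > 50000 nM in a functional assay on HeLa cells (Homo sapiens) for antiproliferative activity, with a stated time of 24 h (on this read-out lower numbers stand for stronger inhibition and higher numbers for weaker inhibition), which is a limit of the assay.
Compound 2 `Cc1ccc(C(=O)Nc2sc3c(c2C(N)=O)CCN(Cc2ccc(Cl)cc2Cl)C3)cc1` gives > 50000 nM in this assay, again a limit of the assay.
Compound 3 `NC(=O)c1c(NC(=O)c2cccc([N+](=O)[O-])c2)sc2c1CCN(Cc1ccc(Cl)cc1Cl)C2` gives 33000 nM in this assay.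

Compound 1 thus stands at the limit of > 50000 nM in this assay, at which 2 of the 3 values shown sit, and from there only floors can be read. The step that the two limits leave unreadable from compound 1 to compound 2 is unreadable between two limits. Going by the values given here, the steps of an at least 1.5-fold lower number from compound 1 to compound 3 (0.18 log units; that floor lies within the scatter) and an at least 1.5-fold lower number from compound 2 to compound 3 (0.18 log units; that floor lies within the scatter) carry floors that lie within the scatter, so none of the measured changes shows a movement that is secure.

Compound 4 `NC(=O)c1c(NC(=O)c2ccc(C(F)(F)F)cc2)sc2c1CCN(C(=O)Nc1ccccc1Cl)C2` differs from compound 1 by (2-chlorophenyl)carbamoyl in place of 2,4-dichlorobenzyl on an amine nitrogen in a ring. Among the compounds with values here, all three measured steps alter the aryl on the carbonyl carbon; none touches the amine nitrogen in the ring, so no measured step bears on this change. With compound 1 itself at the limit, the expectation for compound 4 is no step beyond the scatter, and the step of a number no higher from compound 1 to compound 4 (the limit leaves the size open) is an estimate of that kind. Compound 4 is therefore expected to give about 50000 nM, in the range 20000 nM to 150000 nM, most likely as a limit again.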

Compound 4, half-maximal inhibitory concentration: > 50000 nM
Compound 4 ended at the assay's limit; the forecaster's own chance of this, stated with the estimate: 70%; the middle value lies on the limit itself.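

Compound 1 and compound 4 both sit at a limit of the assay, so no step between them can be read: the limit of > 50000 nM in this assay, at which 3 of the 4 values shown sit.

The compounds shown leave open whether (2-chlorophenyl)carbamoyl in place of 2,4-dichlorobenzyl on an amine nitrogen in a ring changes the read-out in this assay at all.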